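Swapping the aryl on a thiazole hydrazone: compound 1 to 4

The source may hold more compounds than are shown below. What is called first, only, known or untested is meant among the compounds shown, and "the series" means these compounds.

Measured compounds:
compound 1, `COc1ccccc1-c1csc(N/N=C/c2ccc(F)c(F)c2)n1`, 40600 nM
compound 2, `COc1cc(/C=N/Nc2nc(-c3ccccc3)cs2)cc(Br)c1OC`, 74100 nM
compound 3, `COc1cc(/C=N/Nc2nc(-c3ccc(F)c(F)c3)cs2)cc(Br)c1OC`, 26300 nM

In a functional assay on U-87MG ATCC cells for inhibition, with U-87 MG (Homo sapiens) as the target, read by MTT assay, with a stated time of 48 h (a higher number here means a weaker inhibitor, a lower number a stronger inhibitor), compound 1 stands second highest of the three numbers, within the scatter of both compound 3 and compound 2. Compound 4, `Fc1ccc(/C=N/Nc2nc(-c3cccc(Br)c3)cs2)cc1F`, differs from compound 1 in one place: 3-bromophenyl in place of 2-methoxyphenyl on an aromatic carbon. Going by the values given here, one measured step touches the same aromatic carbon of the five-membered ring, where a 2.8-fold lower number from compound 2 to compound 3 (0.45 log units; beyond the scatter), a modest change with a different pair of groups. With bromine entering and methoxy leaving, nothing more than a small movement is expected, and for compound 4 the expected step is a 1.4-fold lower number from compound 1 to compound 4 (0.13 log units; within the scatter), which lies within the scatter. Compound 4 is therefore estimated at 30000 nM, with a range from 10000 nM to 90000 nM.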

Compound 4, half-maximal inhibitory concentration: 39900 nM
Compound 4: the middle estimate sits 1.3-fold (0.12 log units) below what was measured; low and high end bracket the measured number.
By their numbers in this assay, from the lowest: compounds 3, 4, 1 and 2 (each within the scatter of the next, the first and the last beyond it).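

In this assay, putting 3-bromophenyl in place of 2-methoxyphenyl on this aromatic carbon gives a 1.0-fold lower number from compound 1 to compound 4 (0.01 log units; within the scatter), so this exchange leaves the number unmoved. The position therefore does not respond to every change of aryl group, although the earlier exchange of phenyl for 3,4-difluorophenyl gave a 2.8-fold lower number from compound 2 to compound 3 (0.45 log units; beyond the scatter), on a different hydrazone partner. Nothing at hand explains this difference between the two exchanges. The compounds shown leave open whether an aryl group carrying an amine or a carboxylic acid at this place would move the number beyond the scatter.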